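The source may hold more compounds than are shown below. What is called first, only, known or untested is meant among the compounds shown, and "the series" means these compounds.

Measured compounds:
- Compound 1, `C#CCN(c1nc2ccc(F)cc2s1)c1nc2ccc(OC)cc2s1`, gives 27800 nM in a functional assay on MCF7 cells (Homo sapiens) for antiproliferative activity, read by MTT assay; a higher number here means a weaker inhibitor, a lower number a stronger inhibitor.
- Compound 2, `COc1ccc2nc(N(Cc3cc(-c4ccc(SC(F)(F)F)cc4)no3)c3nc4ccc(F)cc4s3)sc2c1`, gives 14100 nM in this assay.

Compound 2 has the lower of the two numbers, but its gap to compound 1 lies within the usual scatter of this kind of measurement, so the two cannot be told apart on these results. The unmeasured compound 3, `COc1ccc2nc(N(Cc3cc(-c4ccc(OC(F)(F)F)cc4)no3)c3nc4ccc(F)cc4s3)sc2c1`, shares the whole of compound 2 apart from one group on the outer six-membered ring: trifluoromethoxy in place of (trifluoromethyl)sulfanyl on an aromatic carbon. Among the compounds with values here, the two groups match in their count of heavy atoms and hydrogen-bond acceptors, and no measured pair shows what such a swap does here. The step from compound 2 to compound 3 in this assay is expected to be a 1.1-fold higher number from compound 2 to compound 3 (0.03 log units; within the scatter), that is, no change beyond the scatter in either direction. Compound 3 is therefore estimated to give 15000 nM in this assay, with a range from 5000 nM to 45000 nM.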

Compound 3, half-maximal inhibitory concentration: 17400 nM
The estimate for compound 3 lay 1.2-fold (0.06 log units) below the measured number, within the range that was stated.
By their numbers in this assay, from the lowest: compounds 2, 3 and 1 (each within the scatter of the next).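

In this assay, within the data shown here, the exchange of (trifluoromethyl)sulfanyl for trifluoromethoxy on the outer six-membered ring gives a 1.2-fold higher number from compound 2 to compound 3 (0.09 log units; within the scatter) and so offers the first direct look at a single change in these compounds. At this place, para to a large group, the two groups cannot be told apart, so an oxygen can stand in for the sulfur without a change that rises above the scatter. Nothing measured here gives a reason for this result.

The two groups match in their count of heavy atoms and hydrogen-bond acceptors, so this one pair says little about how far the position tolerates a different kind of group. On these data alone, whether an amine or a carboxylic acid at this place would move the number beyond the scatter remains open.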